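Working notes: from compound 1 to compound 4

The compounds below may be only part of what the source reports. "The series", "measured", "known", "first", "only" and "open" are said of these compounds alone.

Three compounds have numbers in an assay on cells for inhibition of HSP60/HSP10 (Homo sapiens), with a stated time of 60 min; a higher number here means a weaker inhibitor, a lower number a stronger inhibitor:
compound 1 `O=S(=O)(Nc1ccc2oc(-c3ccccc3)nc2c1)c1ccccc1Cl` gives > 100000 nM.
compound 2 `O=S(=O)(Nc1ccc(-c2nc3cc(NS(=O)(=O)c4ccccc4)ccc3o2)cc1)c1ccccc1` gives 80000 nM.
compound 3 `O=S(=O)(Nc1ccc(-c2nc3cc(NS(=O)(=O)c4cccc(O)c4)ccc3o2)cc1)c1cccc(O)c1` gives 17000 nM.

For compound 1 the value is a limit of this assay, not a number, (the limit of > 100000 nM in this assay, at which 1 of the 3 values shown sits). Compound 2 and compound 3 carry numbers, and compound 3 sits at the stronger end of the three while compound 1 stands at the weak end with no number at all.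

Compound 4 `COc1ccccc1S(=O)(=O)Nc1ccc2oc(-c3ccccc3)nc2c1` differs from compound 1 in one place: methoxy in place of chloro on an aromatic carbon. For the measured compounds named here, no measured pair shows such a change, so no step size can be read from the series. The expectation for compound 4 is a step of a number no higher from compound 1 to compound 4 (the limit leaves the size open), that is, nothing beyond the scatter. Compound 4 is thus estimated at 100000 nM, between 30000 nM and 300000 nM.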

Compound 4, half-maximal inhibitory concentration: > 100000 nM
Compound 4: a limit, no number (the forecaster's own chance of this, stated with the estimate: 60%); the middle value sits exactly at the limit.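

Compound 1 and compound 4 each carry a limit of the assay and not a number, so no step between them can be read: the limit of > 100000 nM in this assay, at which 2 of the 4 values shown sit.

In this assay, as far as these compounds go, the effect of methoxy in place of chloro on an aromatic carbon, if any, stays open.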